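Replacing a fluorophenyl with a naphthyl on the carbonyl

The source may hold more compounds than are shown below. What is called first, only, known or untested is meant among the compounds shown, and "the series" means these compounds.

Of the compounds shown here, three sharing one core have been tested in a functional assay on MCF7 cells (Homo sapiens) for cytotoxicity, read by MTT assay, with a stated time of 48 h; on this read-out higher numbers stand for weaker inhibition and lower numbers for stronger inhibition. Compound 1 `COc1cc(-c2nnc3n2NC(c2ccco2)C(C(=O)c2ccccc2F)S3)cc(OC)c1OC` gives 94800 nM. Compound 3 `COc1cc(C(=O)C2Sc3nnc(-c4cc(OC)c(OC)c(OC)c4)n3NC2c2cccs2)cc(OC)c1OC` gives 71000 nM, a number within the scatter of that of compound 1. Compound 2 `COc1cc(-c2nnc3n2NC(c2cccs2)C(C(=O)c2ccc(F)cc2)S3)cc(OC)c1OC` gives 43700 nM, a lower number than compound 1 by more than the scatter.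

Compound 4 `COc1cc(-c2nnc3n2NC(c2ccco2)C(C(=O)c2cccc4ccccc24)S3)cc(OC)c1OC` differs from compound 1 by naphthalen-1-yl in place of 2-fluorophenyl on a carbonyl carbon. Among the compounds with values here, the only measured step touching the same place is a 1.6-fold higher number from compound 2 to compound 3 (0.21 log units; within the scatter), an exchange of the aryl group on the carbonyl carbon that left the number essentially unchanged. Within the data shown here, nothing measured here speaks for a large effect of changing that aryl group, so no step beyond the scatter is expected in this assay, though the one comparable step is a single observation on a different pair. On that basis compound 4 is estimated at 75000 nM, with a likely range from 25000 nM to 200000 nM, which means an expected step of a 1.3-fold lower number from compound 1 to compound 4 (0.10 log units; within the scatter).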

Compound 4, half-maximal inhibitory concentration: > 100000 nM
Compound 4: only a limit was reported; the forecaster's own chance of this, stated with the estimate: 15%; middle value at least 1.3-fold (0.12 log units) away from the limit.
By their numbers in this assay, from the lowest: compounds 2, 3 and 1 (each within the scatter of the next, the first and the last beyond it). At a limit, above all of these: compound 4.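

In this assay compound 4 gives only a limit, > 100000 nM, and not a number. The change can therefore be read only as a floor, an at least 1.0-fold higher number from compound 1 to compound 4 (0.02 log units; that floor lies within the scatter), so naphthalen-1-yl on the carbonyl carbon gave no stronger inhibition, but how much weaker the true number may be cannot be told. What the earlier compounds did not show is that an aryl group with two six-membered aromatic rings at this place takes the reading to the end of the measurable range: the limit of > 100000 nM in this assay, at which 1 of the 4 values shown sits.

Going by these compounds, it remains open whether an aryl group carrying an amine or a carboxylic acid at this place would bring the number down. On these data alone, it is also open whether naphthalen-1-yl would act the same way on the core of compound 2.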